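A hydroxy group on the ring of compound 3

The source may report more compounds than this note shows. Statements on the series, on what has been measured and on what is new or still open speak of the compounds shown alone.

Three compounds have been tested in a functional assay for inhibition of sodium/hydrogen exchanger (Oryctolagus cuniculus); a higher number here means a weaker inhibitor, a lower number a stronger inhibitor:
compound 1, `Cc1cc(-c2ccccc2)c(S(C)(=O)=O)cc1C(=O)N=C(N)N`, gives 19 nM
compound 2, `COc1cc(C)c(C(=O)N=C(N)N)cc1S(C)(=O)=O`, gives 16 nM
compound 3, `Cc1cc(N2CCCCC2)c(S(C)(=O)=O)cc1C(=O)N=C(N)N`, gives 21 nM

All three share one core and differ only in the group on one aromatic carbon. The steps between them are small: a 1.2-fold lower number from compound 1 to compound 2 (0.07 log units; within the scatter), a 1.1-fold higher number from compound 1 to compound 3 (0.04 log units; within the scatter) and a 1.3-fold higher number from compound 2 to compound 3 (0.12 log units; within the scatter). Compound 3 has the highest number of the three, but its gaps to compound 1 and compound 2 lie within the scatter, so no order among the three can be read.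

Compound 4, `Cc1cc(N2CCCC(O)C2)c(S(C)(=O)=O)cc1C(=O)N=C(N)N`, is not yet measured. It differs from compound 3 in one place: hydroxy in place of hydrogen on a saturated ring carbon. Going by the values given here, no measured step touches this ring, so nothing bears on the change directly; the three measured steps show only that exchanging the whole group on that aromatic carbon for quite different groups left this assay unmoved. On that basis a step within the scatter, in either direction, is expected for compound 4, a 1.0-fold higher number from compound 3 to compound 4 (0.02 log units; within the scatter). The estimate for compound 4 in this assay is 22 nM, with a range from 8 nM to 60 nM.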

Compound 4, half-maximal inhibitory concentration: 30 nM
Compound 4: middle estimate off by 1.4-fold (0.13 log units), on the low side; measured number inside the range.
By their numbers in this assay, from the lowest: compounds 2, 1, 3 and 4 (each within the scatter of the next).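

The hydroxy group on this saturated ring carbon, the only change shown on the ring itself, gives a 1.4-fold higher number from compound 3 to compound 4 (0.15 log units; within the scatter) in this assay, so a hydrogen-bond donor and acceptor can sit at this place without a step that stands out from the scatter. The 3-hydroxypiperidin-1-yl group also stays close to the two other groups on the aromatic carbon, with a 1.9-fold higher number from compound 2 to compound 4 (0.27 log units; within the scatter) and a 1.6-fold higher number from compound 1 to compound 4 (0.20 log units; within the scatter), so the four compounds still show no order. No other data bear on this result.

As far as these compounds go, whether an amine or a carboxylic acid on the same ring carbon would also stay within the scatter remains open. Equally open, from the compounds shown here alone, is whether a hydroxy group on a different carbon of this ring would give a similar number.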